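The source may report more compounds than this note shows. Statements on the series, on what has been measured and on what is new or still open speak of the compounds shown alone.

Three compounds of the series have readings in a functional assay on A549 cells (Homo sapiens) for cytotoxicity, read by MTT assay, with a stated time of 68 h; a higher number here means a weaker inhibitor, a lower number a stronger inhibitor. Compound 1 `COc1ccc(-c2cc(NC(=O)C(Cl)Cl)cc(-c3ccc(OC)cc3)c2)cc1` gives 20800 nM. Going by the values given here, compound 2 `O=C(Nc1cccc(-c2cccc(F)c2)c1)C(Cl)Cl` gives 9530 nM, the lower of the two numeric values so far, and its gap to compound 1 lies beyond the usual scatter. Compound 3 `O=C(Nc1cccc(-c2nccs2)c1)C(Cl)Cl` reads > 50000 nM, which is a limit of the assay and not a number.

Next in line is compound 4 `O=C(Nc1cccc(-c2cccc(Cl)c2)c1)C(Cl)Cl`, which carries chloro in place of fluoro on an aromatic carbon, meta to a large group (chloro in place of fluoro on an aromatic carbon). Among the compounds with values here, no measured pair shows this exchange, so the expectation rests on compound 2 at 9530 nM and on the small size of the structural change. In this assay, a step within the scatter is expected, with only a slight lean toward a lower number. The expected step is a 1.2-fold lower number from compound 2 to compound 4 (0.08 log units; within the scatter). For compound 4 the estimated value is 8000 nM, with an expected range of 3500 nM to 18000 nM.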

Compound 4, half-maximal inhibitory concentration: 21400 nM
For compound 4 the middle estimate is 2.7-fold (0.43 log units) below the measured one; measured number above the stated range.
By their numbers in this assay, from the lowest: compound 2; then compounds 1 and 4 (each within the scatter of the next). At a limit, above all of these: compound 3.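

Going by these compounds alone, this is the first step between two compounds that differ in one place: on an aromatic carbon, meta to a large group, chloro in place of fluoro gives a 2.2-fold higher number from compound 2 to compound 4 (0.35 log units; beyond the scatter) in this assay. The reading at this position therefore moves beyond the scatter on the exchange of one heavy atom for another, with no change in hydrogen-bond donors, hydrogen-bond acceptors or net charge. No measured property shown here accounts for this step.

On these data alone, with one pair, it remains open whether the same exchange elsewhere on this ring would give a step of similar size. As far as these compounds go, how an amine, a hydroxyl or a carboxylic acid on this aromatic carbon would read in this assay also remains open.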